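The source may hold more compounds than are shown below. What is called first, only, known or untested is meant among the compounds shown, and "the series" means these compounds.

In a functional assay on SK-BR-3 cells (Homo sapiens) for inhibition, read by MTT assay, with a stated time of 2 days, tested at 10 uM (a higher number here means more inhibition of growth at the concentration tested, a lower number less inhibition of growth), the measured compounds are:
- compound 1 `CNC(=O)c1cc(Oc2ccc3nc(NC(=O)c4ccc(Cl)cc4Cl)sc3c2)ccn1`: 14%
- compound 2 `CNC(=O)c1cc(Oc2ccc3nc(NC(=O)Nc4ccc(C5CCN(C(C)C)CC5)cc4)sc3c2)ccn1`: 45%
- compound 3 `CNC(=O)c1cc(Oc2ccc3nc(NC(=O)c4cccc(F)n4)sc3c2)ccn1`: 12.5%

Compound 1 stands second highest of these three. Its nearest neighbour is compound 3, reached by a number 1.5 percentage points lower from compound 1 to compound 3 (within the scatter), a change that swaps one ring for another on the carbonyl carbon and leaves the rest untouched. Compound 2, whose number is clearly higher, differs from compound 1 in more than one place, so its value gives only a hint. Compound 4 `CNC(=O)c1cc(Oc2ccc3nc(NC(=O)Nc4ccc(Cl)cc4Cl)sc3c2)ccn1` differs from compound 1 by (2,4-dichlorophenyl)amino in place of 2,4-dichlorophenyl on a carbonyl carbon. Going by the values given here, no measured step follows exactly this change, so the expectation rests on compound 2 and stays loose. The step expected for compound 4 in this assay is a number 11 percentage points higher from compound 1 to compound 4 (beyond the scatter). Compound 4 is estimated at 25%, within 8% to 45%.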

Compound 4, percent growth inhibition at one concentration: 22.3%
Compound 4: the middle estimate sits 2.7 percentage points above what was measured, within the range that was stated.
By their numbers in this assay, from the lowest: compounds 3, 1 and 4 (each within the scatter of the next); then compound 2.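

In this assay, (2,4-dichlorophenyl)amino in place of 2,4-dichlorophenyl on the carbonyl carbon gives a number 8.3 percentage points higher from compound 1 to compound 4 (within the scatter), so adding the nitrogen with its hydrogen-bond donor does not clearly separate these two compounds. Against 6-fluoropyridin-2-yl, the same group gives a number 9.8 percentage points higher from compound 3 to compound 4 (within the scatter), so all three groups compared at this carbon read alike. Nothing available explains these readings. On these data alone, what a morpholine ring or a carboxylic acid on the phenyl ring of compound 4 would do remains open, as does the effect of a longer chain on the carbonyl carbon.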